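The source may hold more compounds than are shown below. What is called first, only, known or untested is meant among the compounds shown, and "the series" means these compounds.

Working notes on the ester series, read in a functional assay on LoVo cells (Homo sapiens) for inhibition, read by MTT assay, with a stated time of 48 h; a higher number here means a weaker inhibitor, a lower number a stronger inhibitor. Compound 1 `COc1ccc(N(C)c2nc(C)nc3ccccc23)cc1C(=O)OCC[Se]C#N` gives 2960 nM, compound 2 `COc1ccc(N(C)c2nc(C)nc3ccccc23)cc1C(=O)OCCC[Se]C#N` gives 854 nM and compound 3 `COc1ccc(N(C)c2nc(C)nc3ccccc23)cc1C(=O)OCCCC[Se]C#N` gives 1080 nM. Compound 3 therefore stands within the scatter of compound 2, and both lie beyond the scatter under compound 1.

Compound 4 `COc1ccc(N(C)c2nc(C)nc3ccccc23)cc1C(=O)OCCCCCC[Se]C#N` departs from compound 3 by a group of 5 heavy atoms (3 carbon, 1 nitrogen, 1 selenium; no ring) in place of a group of 3 heavy atoms (1 carbon, 1 nitrogen, 1 selenium; no ring), on a saturated chain carbon, four bonds along the chain from an oxygen next to a carbonyl group, on a saturated chain carbon, four bonds along the chain from an oxygen next to a carbonyl group.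

Three measured chain extensions bear on this change. The closest in counted size is a 2.7-fold lower number from compound 1 to compound 3 (0.44 log units; beyond the scatter), a modest gain, and the smaller extension gave a 3.5-fold lower number from compound 1 to compound 2 (0.54 log units; beyond the scatter), also modest. The most recent extension, however, gave a 1.3-fold higher number from compound 2 to compound 3 (0.10 log units; within the scatter), which is within the scatter. For the measured compounds named here, only the steps leaving compound 1 moved the number, and three compounds make this plateau a tentative reading. Going by the values given here, no measured chain is as long as the one in compound 4, so a drift in either direction remains open.

No step beyond the scatter is expected in this assay. The expected step is a 1.1-fold lower number from compound 3 to compound 4 (0.03 log units; within the scatter). Compound 4 is estimated at 1000 nM, with an expected range of 400 nM to 2800 nM.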

Compound 4, half-maximal inhibitory concentration: 1050 nM
The estimate for compound 4 lay 1.1-fold (0.02 log units) below the measured number; measured number inside the range.
By their numbers in this assay, from the lowest: compounds 2, 4 and 3 (each within the scatter of the next); then compound 1.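

In this assay, the longest chain shown adds no movement, since a 1.0-fold lower number from compound 3 to compound 4 (0.01 log units; within the scatter) and a 1.2-fold higher number from compound 2 to compound 4 (0.09 log units; within the scatter) both stay within the scatter. The plateau among compound 2, compound 3 and compound 4 therefore no longer rests on a single step, and it now extends to a group of 5 heavy atoms in place of a group of 3 heavy atoms, on a saturated chain carbon, four bonds along the chain from an oxygen next to a carbonyl group. Among the new steps, only a 2.8-fold lower number from compound 1 to compound 4 (0.45 log units; beyond the scatter) lies beyond the scatter, and it is a modest one, while no accompanying measurement offers an explanation for the plateau.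

From the compounds shown here alone, whether a chain longer than that of compound 4 would stay on this plateau remains open. So does whether it would hold with an amide in place of the ester, or with a thiocyanate in place of the selenium-bearing end group.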